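Quinone amino-acid series: glycine to valine side chain

This account rests on a few compounds, and the source may have more. Where it says the series, first, only, none or still open, it means among the compounds named here.

Compound 1 `CC(C)(C)C1=CC(=O)C=C(NCC(=O)O)C1=O` is the smaller core. In a functional assay on K562 cells (Homo sapiens) for cytotoxicity, read by MTT assay, with a stated time of 72 h (on this read-out higher numbers stand for weaker inhibition and lower numbers for stronger inhibition), compound 1 gives 85000 nM. Compound 3 `CC(C)[C@@H](NC1=CC(=O)C=C(C(C)(C)C)C1=O)C(=O)O` differs from compound 1 by isopropyl in place of hydrogen on a saturated chain carbon bound to an amine nitrogen and a carbonyl carbon. This change gives a 1.5-fold lower number from compound 1 to compound 3 (0.17 log units; within the scatter). In this assay compound 3 gives 57800 nM.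

Compound 2 `CC1=CCC[C@H]2[C@](C)(CC3=CC(=O)C=C(NCC(=O)O)C3=O)[C@@H](C)CC[C@]12C` carries a larger core in place of the core of compound 1; the difference between the two cores is not broken down here. In this assay compound 2 gives 15600 nM, the lowest of the three numbers measured, and its gaps to compound 1 and to compound 3 both lie beyond the scatter.

Compound 4 `CC1=CCC[C@H]2[C@](C)(CC3=CC(=O)C=C(N[C@@H](C(=O)O)C(C)C)C3=O)[C@@H](C)CC[C@]12C` is not yet measured. Compound 4 differs from compound 2 by isopropyl in place of hydrogen on a saturated chain carbon bound to an amine nitrogen and a carbonyl carbon. Within the data shown here, this is the same change as that from compound 1 to compound 3, at the same place, so the only precedent for it is the single pair of compound 1 and compound 3. Among the measured compounds shown here, with that step being a 1.5-fold lower number from compound 1 to compound 3 (0.17 log units; within the scatter), a step of a 1.4-fold lower number from compound 2 to compound 4 (0.15 log units; within the scatter) is expected for compound 4, since the one earlier instance stayed within the scatter and nothing else bears on the change. For the measured compounds named here, compound 4 is therefore expected to give about 11000 nM in this assay, with the range 4000 nM to 30000 nM reflecting that only one prior example, on a different core, supports the estimate.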

Compound 4, half-maximal inhibitory concentration: 7780 nM
Estimate against measurement, compound 4: 1.4-fold (0.15 log units) above; measured number inside the range.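

Replacing hydrogen with isopropyl on the saturated chain carbon bound to an amine nitrogen and a carbonyl carbon gives, on the larger core, a 2.0-fold lower number from compound 2 to compound 4 (0.30 log units; within the scatter) in this assay. Set beside the same change on the smaller core, the two steps do not separate: the same change on two cores in this assay, a 1.5-fold lower number (0.17 log units; within the scatter) from compound 1 to compound 3 and a 2.0-fold lower number (0.30 log units; within the scatter) from compound 2 to compound 4, 1.4-fold (0.13 log units) apart, within the scatter of two such steps. The change therefore carries from the core of compound 1 to the core of compound 2 with no step beyond the scatter on either core, but this rests on two pairs in one assay, and it neither establishes a real effect of isopropyl on either core nor gives a rule for any other core.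

Still open, on these data alone, is whether a different group at this place, such as a benzyl group, a longer alkyl chain or a chain ending in an amine, would give a step beyond the scatter on either core. Also open, as far as these compounds go, is what an amide or a methyl ester in place of the carboxylic acid would give in this assay.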